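The compounds below may be only part of what the source reports. "The series", "measured", "known", "first", "only" and "open" are said of these compounds alone.

Working notes on the series. Compound 1, `COc1cc2nc(NCc3ccccc3)nc(NC3CCCCCC3)c2cc1OC`, was tested in an in vitro assay on B300-19 cells for displacement of a labelled ligand from C-C chemokine receptor type 4 (Homo sapiens), tested at 1 uM; a lower number here means less inhibition, a higher number more inhibition at the concentration tested (going by the name of the read-out). In this assay compound 1 gives only a limit, < 0%, not a number. Compound 2, `COc1ccc2c(NC3CCCCCC3)nc(N3CCC(N4CCCC4)CC3)nc2c1`, shares the core with compound 1 and differs in more than one place, so the pair is taken only for what its two values show. In this assay, among the compounds with values here, compound 2 gives 0%, the one outright number in the set. The other value recorded, that of compound 1, is a limit, as noted in the limit of < 0% in this assay, at which 1 of the 2 values shown sits. Compound 2 therefore stands at essentially no measurable displacement in this assay.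

Compound 3, `c1ccc2c(NC3CCCCCC3)nc(N3CCC(N4CCCC4)CC3)nc2c1`, is not yet measured. It differs from compound 2 by hydrogen in place of methoxy on an aromatic carbon. Within the data shown here, there is no measured step between compounds that differ in one place on which to rest an expectation. Given that compound 2 itself sits at 0% in this assay, the step of no change at the digits printed from compound 2 to compound 3 (within the scatter) is expected to be nil or within the scatter. In this assay compound 3 is therefore estimated to give 0%, with a range from -10% to 12%.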

Compound 3, a percentage reported as inhibition, at one concentration (the size of the read-out at that concentration, not a potency): 0%
Beside the measured number, compound 3's estimate shows no gap at the digits printed; the range from low to high includes it.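

Within the data shown here, the replacement of methoxy by hydrogen on an aromatic carbon, para to a fused ring, gives the first step between compounds that differ in one place, read in this assay: no change at the digits printed from compound 2 to compound 3 (within the scatter). Methoxy at this position is therefore not needed for the read-out to stand where it does in compound 2, and its loss brings no gain in inhibition at the concentration tested; with nothing measurable to lose in compound 2, however, the step cannot show whether methoxy would matter in a compound with measurable displacement. Compound 1 remains the one limit in the set, not a number: the limit of < 0% in this assay, at which 1 of the 3 values shown sits.

Still open, from the compounds shown here alone, is whether any other group on this aromatic carbon, such as a chlorine atom, an amine or a carboxylic acid, would lift the read-out in this assay beyond the scatter. Also open, going by these compounds, is whether methoxy at this position counts for anything on the shared core once a change elsewhere gives measurable displacement.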